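Aryl swap at the shared core: estimating compound 4

The compounds below may be only part of what the source reports. "The series", "measured", "known", "first", "only" and "open" are said of these compounds alone.

Measured so far in an assay on CHO-K1 cells for antagonist activity at adenosine receptor A1 (Homo sapiens), read by a beta-galactosidase reporter, with stated times of 15 min and 6 h; a lower number here means a stronger inhibitor, a higher number a weaker inhibitor:
- compound 1 `Nc1nc(-c2ccco2)nc2sc(CN3CC=CC3)cc12` gives 290 nM
- compound 2 `Nc1nc(-c2cocn2)nc2sc(CN3CC=CC3)cc12` gives 3900 nM
- compound 3 `Nc1nc(-c2cocn2)nc2sc(CN3CC=CCC3)cc12` gives 2960 nM

Compound 2 gives the highest number of the three; compound 3 is within the scatter of it, and compound 1 is well separated, as the step of a 13-fold higher number from compound 1 to compound 2 (1.13 log units; beyond the scatter) shows. The step of a 1.3-fold lower number from compound 2 to compound 3 (0.12 log units; within the scatter) at the saturated chain carbon is within the scatter.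

Compound 4 `N#Cc1ccc(-c2nc(N)c3cc(CN4CC=CC4)sc3n2)cc1` differs from compound 2 by 4-cyanophenyl in place of 1,3-oxazol-4-yl on an aromatic carbon. Among the measured compounds shown here, the only step that bears on this position is the exchange of aromatic groups from compound 1 to compound 2, which was large. A group exchange of the same kind is therefore expected to move this assay by a sizeable step, and with the oxazolyl group leaving, the expected direction is toward a lower number: a 6.5-fold lower number from compound 2 to compound 4 (0.81 log units; beyond the scatter). For compound 4 the expected value in this assay is 600 nM, within a range of 120 nM to 3000 nM.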

Compound 4, inhibition constant: 2350 nM
For compound 4 the middle estimate is 3.9-fold (0.59 log units) below the measured one; the measured number falls inside the stated range.
By their numbers in this assay, from the lowest: compound 1; then compounds 4, 3 and 2 (each within the scatter of the next).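

In this assay the step from 1,3-oxazol-4-yl to 4-cyanophenyl on the shared core, a 1.7-fold lower number from compound 2 to compound 4 (0.22 log units; within the scatter), leaves these two groups not told apart, despite their different ring size and the added nitrile. Furan-2-yl stands apart from both, with an 8.1-fold higher number from compound 1 to compound 4 (0.91 log units; beyond the scatter) alongside a 13-fold higher number from compound 1 to compound 2 (1.13 log units; beyond the scatter), so among the three groups only furan-2-yl gives a separate number. Nothing shown gives a reason for this separation.

Open, going by these compounds, is whether a plain phenyl or a thiophen-2-yl group at this position would fall with furan-2-yl or with the other two. Also open, on these data alone, is whether furan-2-yl stays apart when the six-membered ring sits on the saturated chain carbon.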